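Furan-2-yl for Bromo Carried onto a Second Core

This account rests on a few compounds, and the source may have more. Where it says the series, first, only, none or still open, it means among the compounds named here.

Measured compounds:
compound 1, `CCCn1c(Br)nc2c(N)nc(NCc3ccccc3)nc21`, gives 358 nM in an assay on CHO cells for displacement of a labelled ligand from adenosine receptor A1 (Homo sapiens); a lower number here means a stronger inhibitor, a higher number a weaker inhibitor
compound 2, `CCCn1c(-c2ccco2)nc2c(N)nc(NCc3ccccc3)nc21`, gives 138 nM in this assay
compound 3, `CCCn1c(Br)nc2c(NCc3ccccc3)ncnc21`, gives 5620 nM in this assay

Compounds 1 and 2 share one core and differ in a single place, (furan-2-yl in place of bromo on an aromatic carbon). That change gives a 2.6-fold lower number from compound 1 to compound 2 (0.41 log units; beyond the scatter), a step beyond the usual scatter. Compound 3 sits on a different core; the difference between the two cores is not broken down here. Its value is the highest of the three, well apart from both compound 1 and compound 2.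

Compound 4, `CCCn1c(-c2ccco2)nc2c(NCc3ccccc3)ncnc21`, is not yet measured. It differs from compound 3 by furan-2-yl in place of bromo on an aromatic carbon, the same change as that from compound 1 to compound 2, at a place described in the same words. On the strength of that earlier step, a 2.6-fold lower number from compound 1 to compound 2 (0.41 log units; beyond the scatter), compound 4 is expected to move by about a 2.6-fold lower number from compound 3 to compound 4 (0.41 log units; beyond the scatter) in this assay. The estimate for compound 4 in this assay is therefore 2200 nM, with a likely range from 900 nM to 5500 nM, resting on one prior example only.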

Compound 4, inhibition constant: 546 nM
The estimate for compound 4 lay 4.0-fold (0.61 log units) above the measured number; the whole stated range lies above it.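

In this assay furan-2-yl in place of bromo gives a 10-fold lower number from compound 3 to compound 4 (1.01 log units; beyond the scatter) on the second core, so the direction of the change seen on the core of compound 1 carried over to the core of compound 3. The size of the step did not carry over, and the two steps differ by more than repeated measurements would account for: the same change on two cores in this assay, a 2.6-fold lower number (0.41 log units; beyond the scatter) from compound 1 to compound 2 and a 10-fold lower number (1.01 log units; beyond the scatter) from compound 3 to compound 4, 4.0-fold (0.60 log units) apart, beyond the scatter of two such steps. These two pairs show that the size of this step depends on the core in this series, but they do not show which difference between the cores is responsible, nor that the direction would hold on a third core.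

From the compounds shown here alone, whether other groups on that aromatic carbon, such as a thiophene ring or an amine, would follow furan-2-yl on either core remains open. So does whether a longer chain in place of the propyl group would alter the size of the step.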